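Dichloro to Difluoro on the Aryl Ketone

The compounds below may be only part of what the source reports. "The series", "measured", "known", "first", "only" and "open" are said of these compounds alone.

Compound 1 `COc1cc(-c2cc(/C=C/C(=O)c3ccc(Cl)c(Cl)c3)[nH]n2)cc(OC)c1OC` stands second highest of three numbers in a functional assay on HOP-62 cells (Homo sapiens) for inhibition, read by sulforhodamine B assay, with a stated time of 48 h (a higher number here means a weaker inhibitor of growth, a lower number a stronger inhibitor of growth), where compound 1 gives 7660 nM. Compound 2 `COc1ccc(-c2cc(/C=C/C(=O)c3ccc(N)cc3)[nH]n2)cc1OC` gives 9670 nM and compound 3 `COc1ccc(-c2cc(/C=C/C(=O)c3ccc(N)cc3)[nH]n2)cc1` gives 7490 nM; the values of compounds 1 and 3 lie within the scatter of each other, as do those of compounds 1 and 2. Going by the values given here, the one measured step, a 1.3-fold lower number from compound 2 to compound 3 (0.11 log units; within the scatter), concerns another part of the shared core and does not bear on the change to compound 4 `COc1cc(-c2cc(/C=C/C(=O)c3ccc(F)c(F)c3)[nH]n2)cc(OC)c1OC`, which is 3,4-difluorophenyl in place of 3,4-dichlorophenyl on a carbonyl carbon. Among the compounds with values here, no measured step exchanges the 3,4-dichlorophenyl, so nothing beyond the scatter is expected in this assay. Compound 4 is therefore estimated at 7700 nM, with a range from 3000 nM to 20000 nM, and the step of a 1.0-fold higher number from compound 1 to compound 4 (0.00 log units; within the scatter) is expected to be flat.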

Compound 4, concentration for total growth inhibition: > 100000 nM
Compound 4 ended at the assay's limit; the forecaster's own chance of this, stated with the estimate: 10%; middle value at least 12-fold (1.11 log units) away from the limit.
By their numbers in this assay, from the lowest: compounds 3, 1 and 2 (each within the scatter of the next). At a limit, above all of these: compound 4.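

In this assay the exchange of 3,4-dichlorophenyl for 3,4-difluorophenyl on a carbonyl carbon gives an at least 13-fold higher number from compound 1 to compound 4 (1.11 log units; beyond the scatter), the first step shown at this position and the only one beyond the scatter. The value of compound 4, > 100000 nM, is a limit of the assay and not a number: the limit of > 100000 nM in this assay, at which 1 of the 4 values shown sits. The two groups have the same heavy-atom count, so growth inhibition here depends on which halogen the ring carries, not on that count.

On these data alone, whether an unsubstituted phenyl, a 3,4-dibromophenyl or a 3,4-dimethylphenyl on the same carbonyl carbon would read like compound 1 or like compound 4 remains open.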